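This account rests on a few compounds, and the source may have more. Where it says the series, first, only, none or still open, it means among the compounds named here.

Measured compounds:
- compound 1, `O=[N+]([O-])c1ccccc1CSc1nnc(-c2ccc3c(c2)OCCO3)n1-c1ccccc1`, 26500 nM
- compound 2, `O=[N+]([O-])c1cccc(CSc2nnc(-c3ccc4c(c3)OCCO4)n2-c2ccccc2)c1`, 30100 nM
- compound 3, `Clc1ccccc1CSc1nnc(-c2ccc3c(c2)OCCO3)n1-c1ccccc1`, 17400 nM

All three numbers come from a functional assay on BGC-823 cells (Homo sapiens) for antiproliferative activity, read by MTT assay, with a stated time of 24 h; a lower number here means a stronger inhibitor, a higher number a weaker inhibitor. Compound 1 stands second highest of the three, nearest to compound 2 and furthest from compound 3, yet every gap between them falls within the usual scatter: a 1.1-fold higher number from compound 1 to compound 2 (0.06 log units; within the scatter), a 1.5-fold lower number from compound 1 to compound 3 (0.18 log units; within the scatter) and a 1.7-fold lower number from compound 2 to compound 3 (0.24 log units; within the scatter). The three compounds share one core and differ only in the group on the saturated chain carbon bound to a sulfur.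

Compound 4, `COc1cccc(CSc2nnc(-c3ccc4c(c3)OCCO4)n2-c2ccccc2)c1`, has not yet been measured in this assay. Going from compound 1 to compound 4 the change is 3-methoxyphenyl in place of 2-nitrophenyl on a saturated chain carbon bound to a sulfur. The two measured steps that start from compound 1 each swap this same group, one moving the nitro from the 2-position to the 3-position and one exchanging nitro for chloro, and neither moved the number beyond the scatter. Among the measured compounds shown here, no measured step places a methoxy group here, so the expectation leans on the three compounds together: a step of a 1.1-fold lower number from compound 1 to compound 4 (0.03 log units; within the scatter), with no change beyond the scatter, is expected. For compound 4 the estimate is 25000 nM, within a range from 10000 nM to 60000 nM.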

Compound 4, half-maximal inhibitory concentration: > 100000 nM
Compound 4: a limit, no number; the forecaster's own chance of this, stated with the estimate: 10%; at least 4.0-fold (0.60 log units) between middle value and limit.
By their numbers in this assay, from the lowest: compounds 3, 1 and 2 (each within the scatter of the next). At a limit, above all of these: compound 4.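

The reading for compound 4 in this assay is a limit of the assay and not a number: the limit of > 100000 nM in this assay, at which 1 of the 4 values shown sits.

Among compounds 1, 2 and 3, the group on the saturated chain carbon bound to a sulfur could change without moving the number beyond the scatter, but this change shows that the position does not tolerate every group, with an at least 3.7-fold higher number from compound 1 to compound 4 (0.57 log units; beyond the scatter) and an at least 5.7-fold higher number from compound 3 to compound 4 (0.75 log units; beyond the scatter). Among the compounds shown here, the closest comparison is with compound 2, where the only difference is the exchange of nitro for methoxy, and it gives an at least 3.3-fold higher number from compound 2 to compound 4 (0.52 log units; beyond the scatter), so in this pair that single exchange is enough to take the number beyond the scatter.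

Only compound 4 carries a methoxy group, so the compounds shown cannot tell whether the drop in activity belongs to methoxy in general or to 3-methoxyphenyl in particular. They also leave open how an amine or a carboxylic acid in place of the methoxy would read, and why the methoxy compound stands apart from the other three.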